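The compounds below may be only part of what the source reports. "The series", "measured", "known", "first", "only" and "open" are said of these compounds alone.

Working notes on the series. In a functional assay on A549 cells (Homo sapiens) for inhibition, read by MTT assay, with a stated time of 72 h (a higher number here means a weaker inhibitor, a lower number a stronger inhibitor), compound 1 (`CC(C)(C)n1cc2c(n1)C(=O)CC1(CCN(C(=O)c3cc(-c4ccc(Cl)cc4)nc4ccccc34)CC1)O2`) gives 2330 nM and compound 2 (`COc1ccc(-c2cc(C(=O)N3CCC4(CC3)CC(=O)c3nn(C(C)(C)C)cc3O4)c3ccccc3n2)cc1`) gives 3740 nM while compound 3 (`CC(C)(C)n1cc2c(n1)C(=O)CC1(CCN(C(=O)c3cc(-c4ccc(N)cc4)nc4ccccc34)CC1)O2`) gives 970 nM as the lowest number of the three.

The next change leads to compound 4 (`Cc1cc(C(=O)N2CCC3(CC2)CC(=O)c2nn(C(C)(C)C)cc2O3)c2ccccc2n1`) and is counted as methyl in place of 4-aminophenyl on an aromatic carbon with methyl in place of 4-aminophenyl on an aromatic carbon, next to the ring nitrogen.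

Within the data shown here, three measured steps bear on this, and only indirectly. The change a 1.6-fold higher number from compound 1 to compound 2 (0.21 log units; within the scatter) stays within the scatter, while a 2.4-fold lower number from compound 1 to compound 3 (0.38 log units; beyond the scatter) and a 3.9-fold lower number from compound 2 to compound 3 (0.59 log units; beyond the scatter) are modest. Each swaps one group on an aromatic carbon and keeps the six-membered aromatic ring that compound 4 loses. Among the measured compounds shown here, no measured compound lacks that ring, so the data give no direct precedent and the estimate is loose.

Compound 4 also gives up the amino group, whose arrival brought a 2.4-fold lower number from compound 1 to compound 3 (0.38 log units; beyond the scatter) in the direction of a stronger inhibitor, so a higher number is expected in this assay here. The expected size is a 4.6-fold higher number from compound 3 to compound 4 (0.67 log units; beyond the scatter) as a modest move toward a weaker inhibitor.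

For compound 4 the estimated value is 4500 nM with an expected range from 1500 nM to 14000 nM in this reading.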

Compound 4, half-maximal inhibitory concentration: > 10000 nM
Compound 4 ended at the assay's limit (the forecaster's own chance of this, stated with the estimate: 12%); middle value at least 2.2-fold (0.34 log units) from the limit.
By their numbers in this assay, from the lowest: compound 3; then compounds 1 and 2 (each within the scatter of the next). At a limit, above all of these: compound 4.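

In this assay compound 4 stands at a limit and not at a number: the limit of > 10000 nM in this assay, at which 1 of the 4 values shown sits. With the phenyl ring removed, methyl in place of 4-aminophenyl gives an at least 10-fold higher number from compound 3 to compound 4 (1.01 log units; beyond the scatter), methyl in place of 4-methoxyphenyl gives an at least 2.6-fold higher number from compound 2 to compound 4 (0.42 log units; beyond the scatter) and methyl in place of 4-chlorophenyl gives an at least 4.2-fold higher number from compound 1 to compound 4 (0.63 log units; beyond the scatter). The earlier compounds shown here varied only the substituent on that ring, whereas this result shows that all three compounds with a substituted phenyl at this position give numbers short of the limit and the one with methyl does not, so in this small set the ring itself, and not the amino group alone, goes with a measurable value.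

Going by these compounds, how far beyond the limit compound 4 lies stays open, so the true size of all three steps is unknown. Also open, on these data alone, is whether an aromatic ring is required here or a saturated ring such as cyclohexyl or a longer chain such as butyl would serve, and how an unsubstituted phenyl, or a hydroxyl or acetamide in place of the amino group, would read.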